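This account rests on a few compounds, and the source may have more. Where it says the series, first, only, none or still open, it means among the compounds named here.

Three analogues on one shared core have numbers in an assay on CHO cells for displacement of a labelled ligand from prostaglandin E2 receptor EP3 subtype (Homo sapiens), read by radioligand binding (on this read-out lower numbers stand for stronger inhibition and higher numbers for weaker inhibition), so far. Compound 1 `CC(C)C(c1nnc[nH]1)c1ccc(-c2ccc3cccc(F)c3c2)[nH]c1=O` gives 12 nM. Compound 2 `CC(C)C(/C=C1\CCNC1=O)c1ccc(-c2ccc3cccc(F)c3c2)[nH]c1=O` gives 2.2 nM. Compound 3 `CC(C)C(Cc1nnn[nH]1)c1ccc(-c2ccc3cccc(F)c3c2)[nH]c1=O` gives 34 nM, the highest of the three: a 2.8-fold higher number from compound 1 to compound 3 (0.45 log units; beyond the scatter), and a 15-fold higher number from compound 2 to compound 3 (1.19 log units; beyond the scatter).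

Compound 4 `CC(C)C(Cc1noc(=O)[nH]1)c1ccc(-c2ccc3cccc(F)c3c2)[nH]c1=O` has not been measured yet. It differs from compound 3 in one place: a group of 6 heavy atoms (2 carbon, 2 nitrogen, 2 oxygen; one five-membered aromatic ring with 3 hetero atoms) in place of a group of 5 heavy atoms (1 carbon, 4 nitrogen; one five-membered aromatic ring with 4 hetero atoms), on a saturated chain carbon, two bonds along the chain from an aromatic carbon. The measured steps that bear on this are the two that also swap the ring carried on that chain: a 2.8-fold higher number from compound 1 to compound 3 (0.45 log units; beyond the scatter), a modest shift, and a 15-fold higher number from compound 2 to compound 3 (1.19 log units; beyond the scatter), a large one. Both show that exchanging the five-membered ring there moves the number beyond the scatter, but neither involves the ring entering compound 4, so the direction is not fixed by them. Compound 3 sits at the weak end of the set, leaving room for a lower number.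

Compound 4 is expected to give about 20 nM, within 6 nM to 70 nM. That estimate implies a step of a 1.7-fold lower number from compound 3 to compound 4 (0.23 log units; within the scatter), expected to stay near or just beyond the scatter.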

Compound 4, inhibition constant: 34 nM
For compound 4 the middle estimate is 1.7-fold (0.23 log units) below the measured one, within the range that was stated.
By their numbers in this assay, from the lowest: compound 2; then compound 1; then compounds 3 and 4 (each within the scatter of the next).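

In this assay, for the compounds shown here, the swap of 1H-tetrazol-5-yl for the five-membered aromatic ring with 3 hetero atoms, on a saturated chain carbon two bonds along the chain from an aromatic carbon, gives no change at the digits printed from compound 3 to compound 4 (within the scatter) and so leaves the number unmoved within the scatter, which the earlier steps, all beyond it, did not show for any ring exchange. The gaps to the other two compounds therefore stay as they were for compound 3, with a 15-fold higher number from compound 2 to compound 4 (1.19 log units; beyond the scatter) as the large step and a 2.8-fold higher number from compound 1 to compound 4 (0.45 log units; beyond the scatter) as the modest one. No measurement offered here accounts for these results.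

Going by these compounds, a carboxylic acid in place of the ring on that chain carbon remains open, as does a longer chain carrying either ring. On these data alone, how the group on compound 2 relates to these rings with only one place changed also remains open.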